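This account rests on a few compounds, and the source may have more. Where it says the series, first, only, none or still open, it means among the compounds named here.

In a functional assay on HeLa cells (Homo sapiens) for inhibition, read by MTT assay, with a stated time of 72 h (a higher number here means a weaker inhibitor, a lower number a stronger inhibitor), the values so far are all limits:
- compound 1 `COc1cc(OC)c(OC)cc1/C=C/C(=O)c1ccccc1` gives > 150000 nM as a limit
- compound 2 `COc1cc(OC)c(OC)cc1/C=C/C(=O)c1ccc(-c2c[nH]cn2)cc1` gives > 150000 nM as a limit
- compound 3 `COc1cc(OC)c(OC)cc1/C=C/C(=O)c1cc(O)ccc1O` gives > 150000 nM as a limit

Compound 1 has no number to start from, only a limit. That limit is shared across the series, which shows the limit of > 150000 nM in this assay, at which 3 of the 3 values shown sit, and nothing more.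

Compound 4 `COc1cc(OC)c(OC)cc1/C=C/C(=O)c1cccc([N+](=O)[O-])c1` is not yet measured and differs from compound 1 by nitro in place of hydrogen on an aromatic carbon (nitro in place of hydrogen on an aromatic carbon, meta to a large group).

Two measured changes bear on this one. The closer is a step that the two limits leave unreadable from compound 1 to compound 2 where a group also replaces hydrogen on an aromatic carbon. The other is a step that the two limits leave unreadable from compound 1 to compound 3 where the phenyl on the carbonyl carbon is exchanged. Neither gives a size, so neither supports a readable step or a direction in this assay for the nitro group.

Compound 4 is therefore expected to stay at or close to the same limit. The expected step is a number no higher from compound 1 to compound 4 (the limit leaves the size open) and the estimate carries no firm direction. For compound 4 the estimate is 150000 nM with an expected range from 50000 nM to 300000 nM in this series.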

Compound 4, half-maximal inhibitory concentration: 130000 nM
Compound 4: middle estimate off by 1.2-fold (0.06 log units), on the high side; low and high end bracket the measured number.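

In this assay, nitro in place of hydrogen on an aromatic carbon, meta to a large group, is the only change shown that gives a measured number rather than a limit, which makes compound 4 the one fixed point in the series so far. On these data alone, the step reads as an at least 1.1-fold lower number from compound 1 to compound 4 (0.06 log units; that floor lies within the scatter); its start is only a limit, so the true size stays open, and what is printed does not separate this change from no change at all. The other steps in the series cannot be read, and the reading of compound 4 sits close to the level where the remaining compounds stop: the limit of > 150000 nM in this assay, at which 3 of the 4 values shown sit.

The compounds shown hold nitro at this one place only, so whether the number belongs to the nitro group or to any group set there, and whether the same group elsewhere on that ring would give a number at all, remains open. An amine or a carboxylic acid at the same place, compared with compound 4 as the measured reference, would give steps between two numbers rather than steps from a limit.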